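Bromine for chlorine on the aryl ketone: compound 3

This account rests on a few compounds, and the source may have more. Where it says the series, first, only, none or still open, it means among the compounds named here.

Among the measured compounds shown here, in a functional assay on the whole organism for inhibition, with Mus musculus as the target, with a stated time of 1 h, at a dose of 30 mg/kg by the intraperitoneal route (a higher number here means more inhibition at the dose given (going by the name of the read-out), a lower number less inhibition), compound 2 `O=C(/C=C/C1=Cc2ccccc2OC1)c1ccc(Cl)cc1` gives 56.1%, the larger of the two numbers so far, but a number 5.1 percentage points higher from compound 1 to compound 2 (within the scatter) lies within the scatter, so compound 1 `O=C(/C=C/C1=Cc2ccccc2OC1)c1cccc(Cl)c1` with 51% is not separated from it. Compound 3 `O=C(/C=C/C1=Cc2ccccc2OC1)c1cccc(Br)c1` differs from compound 2 by 3-bromophenyl in place of 4-chlorophenyl on a carbonyl carbon. For the measured compounds named here, the only step bearing on this change is that from compound 1 to compound 2, and it was within the scatter, so no step beyond the scatter is expected in this assay. Compound 3 is expected at 52%, range 38% to 66%, which is an expected step of a number 4.1 percentage points lower from compound 2 to compound 3 (within the scatter).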

Compound 3, a percentage reported as inhibition, in the whole organism at one dose (the size of the read-out at that dose, not a potency): 51.7%
Estimate against measurement, compound 3: 0.3 percentage points above; low and high end bracket the measured number.
By their numbers in this assay, from the lowest: compounds 1, 3 and 2 (each within the scatter of the next).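

In this assay, among the compounds shown here, bromo in place of chloro on an aromatic carbon gives a number 0.7 percentage points higher from compound 1 to compound 3 (within the scatter) and is the one change here confined to the halogen alone. 3-bromophenyl in place of 4-chlorophenyl on a carbonyl carbon gives a number 4.4 percentage points lower from compound 2 to compound 3 (within the scatter) and likewise separates nothing, so neither the halogen nor its place on the phenyl ring is resolved across these compounds. No measurement at hand offers an explanation of these results.

Still open, from the compounds shown here alone, is whether a group other than a halogen on this phenyl ring, such as an amine or a carboxylic acid, would give a step beyond the scatter.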